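Six-membered ring in place of thiadiazole on compound 2

This account rests on a few compounds, and the source may have more. Where it says the series, first, only, none or still open, it means among the compounds named here.

In a functional assay on HEK293 cells for agonist activity at Bombesin receptor subtype-3 (Homo sapiens), read by luminescence and calcium flux, with a stated time of 10 min (on this read-out lower numbers stand for an effect already at smaller amounts and higher numbers for an effect only at larger amounts of compound), compound 2 `CCC(C)(C)Cc1c[nH]c(CCc2ccc(-c3csnn3)cc2)n1` gives 538 nM, the highest of the three numbers, though only the gap to compound 3 is beyond the scatter. Compound 1 `CCC(C)(C)Cc1c[nH]c(CCc2ccc(-c3ccncc3)cc2)n1` gives 305 nM and compound 3 `CCC(C)(C)Cc1c[nH]c(CCc2ccc(N3CCCCC3)cc2)n1` gives 171 nM. Compound 4 `CCC(C)(C)Cc1c[nH]c(CCc2ccc(-c3ccc(F)cn3)cc2)n1` differs from compound 2 in one place: 5-fluoropyridin-2-yl in place of 1,2,3-thiadiazol-4-yl on an aromatic carbon. The step that bears on this is a 1.8-fold higher number from compound 1 to compound 2 (0.25 log units; within the scatter), the reverse exchange of a six-membered ring with one hetero atom for the thiadiazole; a 3.1-fold lower number from compound 2 to compound 3 (0.50 log units; beyond the scatter) points the same way with a different group. Because compound 1 gives 305 nM with such a ring in the same place, compound 4 is expected near it, so a 1.8-fold lower number from compound 2 to compound 4 (0.25 log units; within the scatter) is the expected step. Compound 4 is estimated at 300 nM, range 120 nM to 800 nM.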

Compound 4, half-maximal effective concentration: 66 nM
Compound 4: middle estimate off by 4.5-fold (0.66 log units), on the high side; the measured number lies below the stated range.
By their numbers in this assay, from the lowest: compound 4; then compounds 3, 1 and 2 (each within the scatter of the next, the first and the last beyond it).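

In this assay, within the data shown here, the position on an aromatic carbon para to a large group tolerates more variation than the earlier compounds showed: an 8.2-fold lower number from compound 2 to compound 4 (0.91 log units; beyond the scatter) is the largest step here so far, and a 2.6-fold lower number from compound 3 to compound 4 (0.41 log units; beyond the scatter) puts 5-fluoropyridin-2-yl ahead of piperidin-1-yl. A six-membered aromatic ring with 1 hetero atom does not by itself set the number, as a 4.6-fold lower number from compound 1 to compound 4 (0.66 log units; beyond the scatter) separates two such rings. Nothing shown here accounts for these steps.

Compound 4 differs from compound 1 in both the ring attachment and the fluorine, so the two remain unseparated. Unsubstituted pyridin-2-yl would separate them, while 5-chloropyridin-2-yl or 5-methoxypyridin-2-yl would test the fluorine's place.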